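A few compounds are considered here, and "the series" means these few. Any claim that something is new, unique, unknown or untested is made for them only; others in the source may bear on it.

Compound 1 `CCCCCCCCN(Cc1ccc(C(=O)NO)cc1)c1ncc(-c2ccc(C)cc2)s1` is the weaker of the two measured members of this series: in a functional assay on PC-3 cells (Homo sapiens) for antiproliferative activity, read by MTT assay, with a stated time of 48 h (a lower number here means a stronger inhibitor of growth, a higher number a weaker inhibitor of growth), compound 1 gives 13300 nM, the highest of the two numbers shown. Its nearest neighbour is compound 2 `Cc1ccc(OCCCN(Cc2ccc(C(=O)NO)cc2)c2ncc(-c3ccc(C)cc3)s2)cc1`, which in this assay gives 9330 nM; the step of a 1.4-fold lower number from compound 1 to compound 2 (0.15 log units; within the scatter) is within the scatter. Compound 3 `CCCN(Cc1ccc(C(=O)NO)cc1)c1ncc(-c2ccc(C)cc2)s1` has not yet been measured. It differs from compound 1 by hydrogen in place of pentyl on a saturated chain carbon, three bonds along the chain from a nitrogen on an aromatic ring. For the measured compounds named here, the only measured step bearing on this position, a 1.4-fold lower number from compound 1 to compound 2 (0.15 log units; within the scatter), exchanged pentyl for 4-methylphenoxy at the same place and left the number essentially unchanged, so that position has so far tolerated substitution without a step beyond the scatter. Going by the values given here, no measured pair removes the pentyl entirely, so the expectation rests on that single neutral step. Compound 3 is therefore expected to fall close to compound 1, the estimated step being a 1.2-fold higher number from compound 1 to compound 3 (0.08 log units; within the scatter), with an expected value of 16000 nM and a range from 6000 nM to 45000 nM.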

Compound 3, concentration for 50% growth inhibition: 9160 nM
Beside the measured number, compound 3's estimate is 1.7-fold (0.24 log units) above it, and the stated range covers the measured number.
By their numbers in this assay, from the lowest: compounds 3, 2 and 1 (each within the scatter of the next).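

Taking the pentyl away altogether, in this assay, gives a 1.5-fold lower number from compound 1 to compound 3 (0.16 log units; within the scatter), so this place needs no pentyl: octyl and propyl on the nitrogen give values within the scatter of each other. The other step, a 1.0-fold lower number from compound 2 to compound 3 (0.01 log units; within the scatter), shows the same for the 4-methylphenoxy, so the chain's far end has now been read with an alkyl group, with an aryl ether and with nothing added, and none of these steps lies beyond the scatter. Nothing available gives a reason for this flat response at this position.

The compounds shown leave open whether any group here can move the number beyond the scatter, for instance an amine or a carboxylic acid on the chain. They also leave open whether a chain cut back to methyl would still stay within it.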